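A few compounds are considered here, and "the series" means these few. Any claim that something is new, unique, unknown or untested is made for them only; others in the source may bear on it.

Working notes on the series.

The shared core is carried by compound 1 `O=C(Nc1ccc(Oc2ccnc3[nH]ccc23)cc1)c1cc2cccnc2n(-c2ccc(Cl)cc2)c1=O` and compound 2 `O=C(Nc1ccc(Oc2ccnc3[nH]ccc23)c(F)c1)c1cc2cccnc2n(-c2ccccc2)c1=O`; the two differ in more than one place, so only their separate readings are noted here. In a functional assay on U-87MG ATCC cells for antiproliferative activity against U-87 MG (Homo sapiens), read by MTT assay, with a stated time of 72 h (a higher number here means a weaker inhibitor, a lower number a stronger inhibitor), compound 1 gives 3370 nM. In this assay compound 2 gives 1260 nM. Compound 3 `O=C(Nc1ccc(Oc2ccnc3[nH]ccc23)c(F)c1)c1cc2cccnc2n(-c2ccc(Cl)cc2)c1=O` combines the ring substituent of compound 1 with the fluorine-bearing aniline of compound 2, but in this assay compound 3 gives "not determined" (no result reported), so no single number for it has been obtained; it has no standing on the values shown and can only be placed by analogy to compound 1 and compound 2.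

Compound 4 `O=C(Nc1ccc(Oc2ccnc3[nH]ccc23)c(F)c1)c1cc2cccnc2n(-c2ccc(F)c(Cl)c2)c1=O` differs from compound 3 by one change: 3-chloro-4-fluorophenyl in place of 4-chlorophenyl on an aromatic nitrogen. Going by the values given here, no step between measured compounds covers this change, so there is nothing to scale it against. Given that the two measured compounds sit within a modest interval of each other, the expectation for this step is a change of no clear direction, most likely none beyond the scatter in this assay.

Compound 4 is therefore expected to give about 2000 nM in this assay, with a plausible range from 600 nM to 6500 nM.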

Compound 4, half-maximal inhibitory concentration: 5230 nM
For compound 4 the middle estimate is 2.6-fold (0.42 log units) below the measured one; the range from low to high includes it.
By their numbers in this assay, from the lowest: compound 2; then compounds 1 and 4 (each within the scatter of the next).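

In this assay, going by these compounds alone, the change at this position reads as a 4.2-fold higher number from compound 2 to compound 4 (0.62 log units; beyond the scatter), with 3-chloro-4-fluorophenyl in place of phenyl on the aromatic nitrogen and the fluorine-bearing aniline held fixed; this is the first reading at this position with the rest of the molecule unchanged, and it shows that the substituted ring here goes with a weaker inhibitor than the unsubstituted phenyl, beyond the scatter. Compound 3 has no number, so the step from it to compound 4 cannot be read, and the added fluorine cannot be separated from the chlorine or from the shift of that chlorine on the ring. Nothing at hand bears on the cause of this step.

The compounds shown leave open whether a single fluorine or a single chlorine on this phenyl ring already accounts for the step, as the one unsubstituted and one doubly substituted reading with this aniline cannot settle that. They also leave open how a methoxy group, a morpholine or a carboxylic acid on this ring would read in this assay.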